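The compounds below may be only part of what the source reports. "The series", "measured", "known", "first", "only" and "open" are said of these compounds alone.

Compound 2 `COc1cc2nc(C(C)C)nc(N3CCN(c4ccccc4OC)CC3)c2cc1OC` and compound 1 `COc1cc2nc(Cc3ccccc3)nc(N3CCN(c4ccccc4OC)CC3)c2cc1OC` share one core and differ only in one group on an aromatic carbon. In an in vitro assay on U2OS cells for agonist activity at neurotensin receptor type 2 (Homo sapiens), read by reporter gene assay and beta-arrestin recruitment (a lower number here means that less compound is needed, a higher number that more compound is needed for the effect), compound 1 gives > 80000 nM, which is a limit of the assay. In this assay compound 2 also gives > 80000 nM, again a limit. The step that the two limits leave unreadable from compound 1 to compound 2 therefore cannot be read, since (the limit of > 80000 nM in this assay, at which 2 of the 2 values shown sit). Compound 3 `COc1cc2nc(C3CCCC3)nc(N3CCN(c4ccccc4OC)CC3)c2cc1OC` carries the change (cyclopentyl in place of isopropyl on an aromatic carbon). With no readable step to build on, compound 3 is expected to stay near that limit, giving an estimated 100000 nM between 30000 nM and 300000 nM, a step that the limit leaves unreadable from compound 2 to compound 3 that is estimated, not measured.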

Compound 3, half-maximal effective concentration: > 80000 nM
Compound 3 was reported as a limit; the forecaster's own chance of this, stated with the estimate: 85%; the middle value lies beyond the limit too.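

No step between compound 1, compound 2 and compound 3 can be read, because all three values are limits and not numbers: the limit of > 80000 nM in this assay, at which 3 of the 3 values shown sit.

The compounds shown leave open how much of any of the three would be needed for the effect in this assay.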